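Chloro to Amino: Expecting the Cytotoxicity of Compound 4

The source may report more compounds than this note shows. Statements on the series, on what has been measured and on what is new or still open speak of the compounds shown alone.

Measured so far:
- compound 1, `Nc1nc(Cl)c2ncn(Cc3ccc(CCl)cc3)c2n1`: 9550 nM
- compound 2, `ClCc1cccc(Cn2cnc3c(Cl)nc(Cl)nc32)c1`: 1900 nM
- compound 3, `ClCc1ccc(Cn2cnc3c(Cl)nc(Cl)nc32)cc1`: 2340 nM

All three were tested in a functional assay on ACHN cells (Homo sapiens) for cytotoxicity, read by sulforhodamine B assay, with a stated time of 48 h; a higher number here means a weaker inhibitor of growth, a lower number a stronger inhibitor of growth. Compound 3 gives 2340 nM, and compound 2 gives 1900 nM; these two numbers lie within the scatter of each other, so neither can be called stronger or weaker than the other. Compound 1 gives 9550 nM, a clearly higher number than either.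

Compound 1 differs from compound 3 in a single place: amino in place of chloro on an aromatic carbon. This change gives a 4.1-fold higher number from compound 3 to compound 1 (0.61 log units; beyond the scatter), so the compound with amino inhibits growth less strongly than its chloro partner.

The unmeasured compound 4, `Nc1nc(Cl)c2ncn(Cc3cccc(CCl)c3)c2n1`, stands in the same relation to compound 2: amino in place of chloro on an aromatic carbon. The place of the change is described in the same words for both pairs, so this is the same change made on a second core. How the core of compound 2 differs from that of compound 3 is not broken down here.

Because the measured pair shows a 4.1-fold higher number from compound 3 to compound 1 (0.61 log units; beyond the scatter), the step from compound 2 to compound 4 is expected to be of similar size, a 4.1-fold higher number from compound 2 to compound 4 (0.61 log units; beyond the scatter), with some room for the cores to differ in their response. Compound 4 is therefore estimated at 7800 nM, expected to fall between 3000 nM and 20000 nM.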

Compound 4, concentration for 50% growth inhibition: 2880 nM
Beside the measured number, compound 4's estimate is 2.7-fold (0.43 log units) above it; measured number outside the range, below it.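

In this assay, the amino-for-chloro change on compound 2 gives a 1.5-fold higher number from compound 2 to compound 4 (0.18 log units; within the scatter), so on this core the swap produces no difference that can be told apart from ordinary repeat scatter. Set beside the earlier pair, the same swap does not give the same result on both cores: the same change on two cores in this assay, a 4.1-fold higher number (0.61 log units; beyond the scatter) from compound 3 to compound 1 and a 1.5-fold higher number (0.18 log units; within the scatter) from compound 2 to compound 4, 2.7-fold (0.43 log units) apart, beyond the scatter of two such steps A step measured on one core therefore could not be carried over unchanged to the other here, even though the swap was the same, on an aromatic carbon lying between two ring nitrogen atoms. Within the data shown here, this does not show why the two cores respond differently, and with only two pairs in one cell assay it gives no rule for which response a further core would follow.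

The compounds shown leave open how other groups on that same aromatic carbon, such as a methylamino or a methoxy group, would behave on each of the two cores. They also leave open whether the two cores would still respond differently to the swap if a hydroxymethyl group stood in place of the chloromethyl group.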